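Enlarging the amine on a long-chain carbamate scaffold

A few compounds are considered here, and "the series" means these few. Any claim that something is new, unique, unknown or untested is made for them only; others in the source may bear on it.

Within the data shown here, compound 2 `CCCCCCCCCCCCCC[C@H](O)[C@H](CN(C(C)C)C(C)C)NC(=O)OC(C)(C)C` stands highest of the two numbers so far: in a functional assay on DLD-1 cells (Homo sapiens) for antiproliferative activity, read by sulforhodamine B assay, with a stated time of 48 h, tested at 10 uM (on this read-out higher numbers stand for more inhibition at the one concentration tested (going by the name of the read-out) and lower numbers for less inhibition), compound 2 gives 34.8%, whereas compound 1 `CCCCCCCCCCCCCC[C@H](O)[C@H](CN(CC)CC)NC(=O)OC(C)(C)C` gives 14.7%. Among the measured compounds shown here, the single measured step, a number 20.1 percentage points higher from compound 1 to compound 2 (beyond the scatter), is the only one bearing on compound 3 `CCCCCCCCCCCCCC[C@H](O)[C@H](CN(CCCC)CCCC)NC(=O)OC(C)(C)C`, whose change is dibutylamino in place of diisopropylamino on a saturated chain carbon, two bonds along the chain from an amide-type nitrogen. Given that a number 20.1 percentage points higher from compound 1 to compound 2 (beyond the scatter) rose beyond the scatter when the amine was enlarged, a further modest rise is expected for compound 3, roughly a number 10.2 percentage points higher from compound 2 to compound 3 (beyond the scatter), although one step is a thin basis. Compound 3 is therefore estimated at 45%, with a range from 25% to 65%.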

Compound 3, a percentage reported as inhibition, at one concentration (the size of the read-out at that concentration, not a potency): 23.4%
Compound 3: middle estimate off by 21.6 percentage points, on the high side; measured number below the stated range.
By their numbers in this assay, from the lowest: compounds 1 and 3 (each within the scatter of the next); then compound 2.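

In this assay, the change to dibutylamino does not continue the earlier rise, giving a number 11.4 percentage points lower from compound 2 to compound 3 (beyond the scatter), while the step from diethylamino is a number 8.7 percentage points higher from compound 1 to compound 3 (within the scatter). On a saturated chain carbon, two bonds along the chain from an amide-type nitrogen, the larger count of heavy atoms in dibutylamino therefore did not bring more inhibition than diisopropylamino, so size alone does not order these three compounds. No measurement offered here accounts for this result. From the compounds shown here alone, it remains open how dipropylamino would read, and whether a ring amine such as piperidine or morpholine would side with diisopropylamino or with the two unbranched amines.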